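Swapping the ring heteroatom in a fatty-acid receptor agonist

The source may report more compounds than this note shows. Statements on the series, on what has been measured and on what is new or still open speak of the compounds shown alone.

Compound 1 `O=C1NC(=O)C(Cc2ccc(Oc3ccc(Cl)cc3Cl)cc2)O1` gives 4020 nM in a functional assay for agonist activity at Free fatty acid receptor 1 (Homo sapiens), read by FLIPR, in the presence of a further agent that is not named here (on this read-out higher numbers stand for an effect only at larger amounts of compound and lower numbers for an effect already at smaller amounts), the highest of the three numbers in hand. Compound 3 `O=C1NC(=O)C(Cc2ccc(/C=C/c3ccccc3)cc2)S1` gives 2090 nM, within the scatter of compound 1, whereas compound 2 `Cc1ccc(Oc2ccc(CC3SC(=O)NC3=O)cc2)cc1` gives 547 nM, beyond it. Compound 4 `O=C1NC(=O)C(Cc2ccc(Oc3ccc(Cl)cc3Cl)cc2)S1` differs from compound 1 by 2,4-dioxo-1,3-thiazolidin-5-yl in place of 2,4-dioxo-1,3-oxazolidin-5-yl on a saturated chain carbon bound to an aromatic carbon. Among the measured compounds shown here, no measured pair isolates this change. Compounds 2 and 3, which also carry the 2,4-dioxo-1,3-thiazolidin-5-yl group, both sit at lower numbers than compound 1, yet they differ in other places too. Compound 4 is therefore expected to show a modest step toward a lower number, a 2.7-fold lower number from compound 1 to compound 4 (0.43 log units; beyond the scatter), with real uncertainty. The estimated value of compound 4 is 1500 nM, in a range from 450 nM to 4500 nM.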

Compound 4, half-maximal effective concentration: 101 nM
Compound 4: the middle estimate sits 15-fold (1.17 log units) above what was measured; the measured number lies below the stated range.
By their numbers in this assay, from the lowest: compound 4; then compound 2; then compounds 3 and 1 (each within the scatter of the next).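

In this assay the change to 2,4-dioxo-1,3-thiazolidin-5-yl in place of 2,4-dioxo-1,3-oxazolidin-5-yl gives a 40-fold lower number from compound 1 to compound 4 (1.60 log units; beyond the scatter) with the rest of the structure unchanged. Among the compounds shown here, this is the first pair to isolate the change, and it shows that exchanging one ring oxygen for sulfur at this place can alone produce a large step. Nothing measured here bears on the reason for that step.

From the compounds shown here alone, whether the step is similar in size with the other groups carried by compound 2 and compound 3 remains open. So does the outcome with a carboxylic acid on this saturated chain carbon.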